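The source may report more compounds than this note shows. Statements on the series, on what has been measured and on what is new or still open speak of the compounds shown alone.

Measured in a functional assay on MCF7 cells (Homo sapiens) for antiproliferative activity, read by MTT assay, with a stated time of 72 h; a higher number here means a weaker inhibitor, a lower number a stronger inhibitor:
- Compound 1 `CC1=CC[C@H]2[C@H](CC[C@]2(C)O)C(C)(C)[C@@H]1CC[C@H]1[C@]2(C)CC[C@H](OC(=O)c3ccc(C)cc3)C(C)(C)O[C@H]2CC[C@@]1(C)O`: > 50000 nM, a limit
- Compound 2 `CC1=CC[C@H]2[C@H](CC[C@]2(C)O)C(C)(C)[C@@H]1CC[C@H]1[C@]2(C)CC[C@H](OC(=O)NCc3ccccc3)C(C)(C)O[C@H]2CC[C@@]1(C)O`: 24500 nM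
- Compound 3 `CC1=CC[C@H]2[C@H](CC[C@]2(C)O)C(C)(C)[C@@H]1CC[C@H]1[C@]2(C)CC[C@H](OC(=O)NS(=O)(=O)c3ccc(C)cc3)C(C)(C)O[C@H]2CC[C@@]1(C)O`: > 50000 nM, a limit

Compound 3 reads > 50000 nM, which is a limit of the assay and not a number. That is the limit of > 50000 nM in this assay, at which 2 of the 3 values shown sit.

Compound 4 `CC1=CC[C@H]2[C@H](CC[C@]2(C)O)C(C)(C)[C@@H]1CC[C@H]1[C@]2(C)CC[C@H](OC(=O)c3ccc(Cl)c(Cl)c3)C(C)(C)O[C@H]2CC[C@@]1(C)O` differs from it by one change, 3,4-dichlorophenyl in place of ((4-methylphenyl)sulfonyl)amino on a carbonyl carbon.

Within the data shown here, three measured steps bear on this: a step that the two limits leave unreadable from compound 1 to compound 3, then an at least 2.0-fold lower number from compound 1 to compound 2 (0.30 log units; that floor lies within the scatter), and finally an at least 2.0-fold higher number from compound 2 to compound 3 (0.30 log units; that floor lies within the scatter). None shows a readable size beyond the scatter. The closest neighbour is compound 1, which also has a substituted phenyl on that carbonyl carbon. Compound 1 gives > 50000 nM, again a limit.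

Only a small step, if any, is therefore expected in this assay, and compound 4 may report only a limit. The expected step is an at least 1.6-fold lower number from compound 3 to compound 4 (0.22 log units; that floor lies within the scatter). Compound 4 is estimated at 30000 nM, with an expected range of 10000 nM to 60000 nM.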

Compound 4, half-maximal inhibitory concentration: 11900 nM
Compound 4: middle estimate off by 2.5-fold (0.40 log units), on the high side; the measured number falls inside the stated range.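

In this assay, a substituted phenyl on this carbonyl carbon can give measurable activity: 3,4-dichlorophenyl in place of 4-methylphenyl gives (an at least 4.2-fold lower number from compound 1 to compound 4 (0.62 log units; beyond the scatter)), and in place of ((4-methylphenyl)sulfonyl)amino it gives (an at least 4.2-fold lower number from compound 3 to compound 4 (0.62 log units; beyond the scatter)). Both steps start from a limit of the assay, so they give only a floor for the true size. Among these compounds, the step from benzylamino (a 2.1-fold lower number from compound 2 to compound 4 (0.31 log units; beyond the scatter)) joins two real numbers and is the first at this position with a known size beyond the scatter, making compound 4 the strongest of the four compounds.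

The compounds shown do not tell whether both chlorines are needed, as a phenyl carrying a single chlorine would show. As far as these compounds go, how a pyridine ring or an amine on this carbonyl carbon would fare also remains open.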